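This account rests on a few compounds, and the source may have more. Where it says the series, first, only, none or still open, it means among the compounds named here.

Series notes on the cathepsin S set. In an assay on isolated protein for inhibition of cathepsin S (Homo sapiens) (a lower number here means a stronger inhibitor, a higher number a weaker inhibitor), compound 1 `COc1cc(C)c(NCCNC(=O)[C@H](CC(C)C)NC(=O)c2cccc(C)c2)c(C)c1` gives 132 nM and compound 2 `COc1ccc(NC[C@@H](C)NC(=O)[C@H](CC(C)C)NC(=O)c2cccc(C)c2)cc1` gives 212 nM. Compound 3 `COc1cccc(C(=O)N[C@@H](CCC2CCCCC2)C(=O)NCCN2CCc3cc(F)ccc32)c1` gives 2130 nM in this assay, the highest of the three numbers; the gap to compound 2 and the wider gap to compound 1 both lie beyond the scatter. No two of these compounds differ in a single place, so no measured single-point step exists in the set. Compound 4 `COc1cccc(C(=O)N[C@@H](CCC2CCCCC2)C(=O)N[C@@H](CO)CN2CCc3cc(F)ccc32)c1` differs from compound 3 by hydroxymethyl in place of hydrogen on a saturated chain carbon bound to an amide-type nitrogen and a saturated chain carbon. Among the compounds with values here, with no comparable step measured, the direction is open; only a small move, if any, is expected, and the step from compound 3 to compound 4 is estimated at a 1.4-fold lower number from compound 3 to compound 4 (0.15 log units; within the scatter). Compound 4 is expected at 1500 nM, within 500 nM to 5000 nM.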

Compound 4, inhibition constant: 50 nM
Estimate against measurement, compound 4: 30-fold (1.48 log units) above; the measured number lies below the stated range.
By their numbers in this assay, from the lowest: compound 4; then compounds 1 and 2 (each within the scatter of the next); then compound 3.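

In this assay, within the data shown here, hydroxymethyl in place of hydrogen on a saturated chain carbon bound to an amide-type nitrogen and a saturated chain carbon gives a 43-fold lower number from compound 3 to compound 4 (1.63 log units; beyond the scatter) and so provides the first measured single-place step in the set. This position is therefore sensitive to substitution, at least on the core of compound 3. No available evidence bears on the reason for a step of this size.

The compounds shown leave open whether the hydroxyl is required or whether methyl, methoxymethyl or aminomethyl on this carbon would give a similar step. As far as these compounds go, the effect of the opposite configuration at this carbon also remains open.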